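A few compounds are considered here, and "the series" means these few. Any claim that something is new, unique, unknown or untested is made for them only; others in the source may bear on it.

Compound 1 `COc1ccc(NC(=O)c2cc3cc(OC)c(OCCCOc4no[n+]([O-])c4S(=O)(=O)c4ccccc4)cc3oc2=O)cc1` gives 5470 nM in an ADME assay on MCF-10A cells (Homo sapiens) for cytotoxicity, read by MTT assay, with a stated time of 48 h; a lower number here means a stronger inhibitor, a higher number a weaker inhibitor.
Compound 2 `COc1cc2cc(C(=O)NCc3ccc(F)cc3)c(=O)oc2cc1OCCCOc1no[n+]([O-])c1S(=O)(=O)c1ccccc1` gives 8460 nM.
Compound 3 `COc1cc2cc(C(=O)NCCCc3ccc(F)cc3)c(=O)oc2cc1OCCCOc1no[n+]([O-])c1S(=O)(=O)c1ccccc1` gives 8920 nM.

Compound 2 stands second highest of the three numbers; a 1.1-fold higher number from compound 2 to compound 3 (0.02 log units; within the scatter) and a 1.5-fold higher number from compound 1 to compound 2 (0.19 log units; within the scatter), both within the scatter, so the three compounds are not separated.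

Compound 4 `COc1ccc(CNC(=O)c2cc3cc(OC)c(OCCCOc4no[n+]([O-])c4S(=O)(=O)c4ccccc4)cc3oc2=O)cc1` differs from compound 2 in one place: methoxy in place of fluoro on an aromatic carbon. Within the data shown here, no measured step isolates this swap. a 1.5-fold higher number from compound 1 to compound 2 (0.19 log units; within the scatter) changes both the ring substituent and the link to the amide nitrogen at once, while a 1.1-fold higher number from compound 2 to compound 3 (0.02 log units; within the scatter) and a 1.6-fold higher number from compound 1 to compound 3 (0.21 log units; within the scatter) change only the chain. All three steps lie within the scatter, so for compound 4 in this assay no step beyond the scatter is expected in either direction. Compound 4 is therefore estimated at 7500 nM, with a range of 3500 nM to 16000 nM. The expected step is a 1.1-fold lower number from compound 2 to compound 4 (0.05 log units; within the scatter).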

Compound 4, half-maximal inhibitory concentration: 5950 nM
Beside the measured number, compound 4's estimate is 1.3-fold (0.10 log units) above it, within the range that was stated.
By their numbers in this assay, from the lowest: compounds 1, 4, 2 and 3 (each within the scatter of the next).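

With the benzyl link held fixed, methoxy in place of fluoro is now read directly, and a 1.4-fold lower number from compound 2 to compound 4 (0.15 log units; within the scatter) in this assay leaves this swap within the scatter. The step of a 1.1-fold higher number from compound 1 to compound 4 (0.04 log units; within the scatter) isolates 4-methoxybenzyl in place of 4-methoxyphenyl, and the step of a 1.5-fold lower number from compound 3 to compound 4 (0.18 log units; within the scatter) changes the amide side chain more broadly; neither separates the compounds. Nothing here gives a cause for these numbers. Still open, from the compounds shown here alone, is whether an amine or a carboxylic acid in place of fluoro or methoxy would give a step beyond the scatter.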